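Swapping the Ring on the Carbonyl of Compound 2

A few compounds are considered here, and "the series" means these few. Any claim that something is new, unique, unknown or untested is made for them only; others in the source may bear on it.

Compound 1 `O=C(/C=C/c1ccc([N+](=O)[O-])cc1)c1ccc[nH]1`: 14000 nM
Compound 2 `O=C(/C=C/c1ccc(Cl)cc1)c1ccc[nH]1`: 13000 nM
Compound 3 `O=C(/C=C/c1ccc(Br)cc1)c1ccc[nH]1`: 32000 nM

In a functional assay on HL-60 cells (Homo sapiens) for inhibition, read by MTT assay, with a stated time of 48 h (on this read-out lower numbers stand for stronger inhibition and higher numbers for weaker inhibition), compound 2 gives the lowest of the three numbers, but the step of a 1.1-fold lower number from compound 1 to compound 2 (0.03 log units; within the scatter) is within the scatter, so the two cannot be ordered. Only compound 3 stands apart, by a 2.5-fold higher number from compound 2 to compound 3 (0.39 log units; beyond the scatter) and a 2.3-fold higher number from compound 1 to compound 3 (0.36 log units; beyond the scatter).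

Compound 4 `O=C(/C=C/c1ccc(Cl)cc1)c1ccco1` differs from compound 2 by furan-2-yl in place of 1H-pyrrol-2-yl on a carbonyl carbon. Among the measured compounds shown here, none of the measured steps touches this place: all three vary the group on the aromatic carbon at the far end. For the measured compounds named here, no step therefore bears on the change to compound 4, and no shift beyond the scatter is expected in this assay, though the range must be wide. Compound 4 is estimated at 13000 nM (range 3000 nM to 60000 nM), a step of no change at the digits printed from compound 2 to compound 4 (within the scatter) from compound 2.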

Compound 4, half-maximal inhibitory concentration: 19000 nM
The estimate for compound 4 lay 1.5-fold (0.16 log units) below the measured number; the range from low to high includes it.
By their numbers in this assay, from the lowest: compounds 2, 1, 4 and 3 (each within the scatter of the next, the first and the last beyond it).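

In this assay, among the compounds shown here, the first change at the carbonyl carbon gives a 1.5-fold higher number from compound 2 to compound 4 (0.16 log units; within the scatter). Furan-2-yl thus replaces 1H-pyrrol-2-yl, trading the ring's hydrogen-bond donor for an acceptor, without a shift beyond the scatter, so this one donor is not shown to matter here. Nothing at hand gives a cause for this result.

Still open, as far as these compounds go, is whether a thiophen-2-yl or phenyl ring on the carbonyl carbon would also leave the number within the scatter. Also open, from the compounds shown here alone, is whether furan-2-yl behaves alike with bromo or nitro at the far end.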